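From Cyclopentyl to Methylthiophene on a Shared Core

The source may hold more compounds than are shown below. What is called first, only, known or untested is meant among the compounds shown, and "the series" means these compounds.

Of the compounds shown here, three with a shared core have been tested in a functional assay on CHO cells for antagonist activity at prostaglandin E2 receptor EP4 subtype (Homo sapiens), read by calcium flux, with a stated time of 15 min; on this read-out lower numbers stand for stronger inhibition and higher numbers for weaker inhibition. Compound 1 `C[C@H](NC(=O)c1cnnn1Cc1ccc(C(F)(F)F)cc1)c1ccc(C(=O)O)cc1` carries hydrogen at the position of interest, and in this assay compound 1 gives only a limit, > 10000 nM. Compound 2 `CCCc1nnn(Cc2ccc(C(F)(F)F)cc2)c1C(=O)N[C@@H](C)c1ccc(C(=O)O)cc1` carries a propyl group there and in this assay gives 68.8 nM. Compound 3 `C[C@H](NC(=O)c1c(C2CCCC2)nnn1Cc1ccc(C(F)(F)F)cc1)c1ccc(C(=O)O)cc1` carries cyclopentyl and in this assay gives 65.1 nM. Compound 3 stands at the lower end of the two numbers shown, but a 1.1-fold lower number from compound 2 to compound 3 (0.02 log units; within the scatter) is within the scatter, so compounds 2 and 3 cannot be separated. Both groups stand far from the hydrogen parent: an at least 140-fold lower number from compound 1 to compound 2 (2.16 log units; beyond the scatter) and an at least 150-fold lower number from compound 1 to compound 3 (2.18 log units; beyond the scatter).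

Compound 4 `Cc1ccc(-c2nnn(Cc3ccc(C(F)(F)F)cc3)c2C(=O)N[C@@H](C)c2ccc(C(=O)O)cc2)s1` is not yet measured. It differs from compound 3 by 5-methylthiophen-2-yl in place of cyclopentyl on an aromatic carbon. The measured steps show that placing a group of this size on that carbon brings the number far down, while exchanging one such group for another changes little. Among the compounds with values here, no measured step exchanges a saturated ring for an aromatic one, so the expectation for compound 4 leans on a 1.1-fold lower number from compound 2 to compound 3 (0.02 log units; within the scatter), where two different groups behave alike. Compound 4 is therefore expected to give in this assay about 80 nM, in a range from 30 nM to 250 nM. That expectation corresponds to an estimated step of a 1.2-fold higher number from compound 3 to compound 4 (0.09 log units; within the scatter), within the scatter.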

Compound 4, half-maximal inhibitory concentration: 4.6 nM
Compound 4: middle estimate off by 17-fold (1.24 log units), on the high side; the measured number lies below the stated range.
By their numbers in this assay, from the lowest: compound 4; then compounds 3 and 2 (each within the scatter of the next). At a limit, above all of these: compound 1.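

In this assay, propyl and cyclopentyl could not be separated, which left it possible that any group of about that size on this aromatic carbon would serve equally well, but 5-methylthiophen-2-yl shows that the identity of the group matters as well as its presence, with a 14-fold lower number from compound 3 to compound 4 (1.15 log units; beyond the scatter) and a 15-fold lower number from compound 2 to compound 4 (1.17 log units; beyond the scatter). Measured against the hydrogen parent, the change amounts to an at least 2100-fold lower number from compound 1 to compound 4 (3.33 log units; beyond the scatter). That last step is a bound and not an exact size, because compound 1 gives only a limit: the limit of > 10000 nM in this assay, at which 1 of the 4 values shown sits.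

The change from cyclopentyl replaces a non-aromatic ring of carbon only with an aromatic ring holding sulfur, and it adds a methyl group as well, so the compounds shown cannot say which of these differences accounts for the step. Thiophen-2-yl without the methyl, phenyl, and 5-chlorothiophen-2-yl on the same carbon are among the groups that would begin to separate these differences, and how far the aromatic ring itself contributes remains open.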